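Swapping a Trifluoromethoxy Group for Chlorine on a Triazolothiadiazine

The source may report more compounds than this note shows. Statements on the series, on what has been measured and on what is new or still open speak of the compounds shown alone.

Of the compounds shown here, three have been measured so far. Compound 1 `CC(c1ccc(-c2ccccc2)c(F)c1)c1nnc2n1N=C(c1ccc(OC(F)(F)F)cc1)CS2` gives 4800 nM in a functional assay on MCF7 cells (Homo sapiens) for inhibition, read by sulforhodamine B assay, with a stated time of 72 h (a lower number here means a stronger inhibitor, a higher number a weaker inhibitor), the strongest inhibition of the three. Compound 2 `COc1ccc2cc(C(C)c3nnc4n3N=C(c3ccc(Cl)cc3Cl)CS4)ccc2c1` gives 14600 nM in this assay, and compound 3 `COc1ccc2cc(C(C)c3n[nH]c(=S)n3N)ccc2c1`, which lacks the fused second ring of the shared core altogether, gives 22300 nM. Both of these lie beyond the usual scatter from compound 1, so compound 1 clearly stands as the most potent of the set. Compound 2 and compound 3 each differ from compound 1 in more than one place, so no single change among the measured compounds can be isolated.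

Compound 4 `CC(c1ccc(-c2ccccc2)c(F)c1)c1nnc2n1N=C(c1ccc(Cl)cc1)CS2` is the next candidate. It is built from compound 1 by one change: chloro in place of trifluoromethoxy on an aromatic carbon. For the measured compounds named here, nothing measured so far tests this particular swap, so there is no direct guide to its effect. Two aromatic substituents of this kind, each without a hydrogen-bond donor, often give similar results, and the expectation is therefore a step of a 1.1-fold higher number from compound 1 to compound 4 (0.06 log units; within the scatter) that does not clearly exceed the scatter. The estimate for compound 4 in this assay is 5500 nM, with a likely range from 2500 nM to 12000 nM.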

Compound 4, half-maximal inhibitory concentration: 8700 nM
Estimate against measurement, compound 4: 1.6-fold (0.20 log units) below; the range from low to high includes it.
By their numbers in this assay, from the lowest: compounds 1, 4, 2 and 3 (each within the scatter of the next, the first and the last beyond it).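

For the compounds shown here, this is the first pair in the set that differs in only one place: the 4-(trifluoromethoxy)phenyl of compound 1 becomes the 4-chlorophenyl of compound 4, and in this assay the change gives a 1.8-fold higher number from compound 1 to compound 4 (0.26 log units; within the scatter). That step lies within the usual scatter of repeated measurements, so on this aromatic carbon, para to a large group, the single heavy atom of chloro can replace the five of trifluoromethoxy without a difference this assay can distinguish. Nothing measured here explains this outcome or describes how the two groups compare in their properties.

As far as these compounds go, whether this position accepts other kinds of group remains open, since neither group here carries a hydrogen-bond donor, and an amine, a carboxylic acid or a longer chain such as butoxy could give quite a different number. From the compounds shown here alone, it is also open whether the swap would give a comparable step with another part of compound 1 changed, a question compound 2 and compound 3 cannot answer because each differs from compound 1 in more than one place.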